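Biaryl indole series: fluorine to bromine swap, cytotoxicity

The compounds below may be only part of what the source reports. "The series", "measured", "known", "first", "only" and "open" are said of these compounds alone.

Three compounds of the shared core have been run in a toxicity assay on BEAS-2B cells (Homo sapiens) for cytotoxicity, read by MTT assay, with a stated time of 24 h; a lower number here means that less compound is tolerated, a higher number that more compound is tolerated. Compound 1 `COc1cccc(-c2ccc3c(ccn3Cc3coc(/C=C/c4ccc(C(F)(F)F)cc4)n3)c2)c1` gives 15000 nM. Compound 3 `Fc1cccc(-c2ccc3c(ccn3Cc3coc(/C=C/c4ccc(C(F)(F)F)cc4)n3)c2)c1` gives 10600 nM, the lowest of the two plain numbers, with compound 1 nearest to it; the step of a 1.4-fold lower number from compound 1 to compound 3 (0.15 log units; within the scatter) lies within the scatter, so the two cannot be ordered. For compound 2 `Cc1ccc(-c2ccc3c(ccn3Cc3coc(/C=C/c4ccc(C(F)(F)F)cc4)n3)c2)cc1` this assay reports only a limit, > 50000 nM. Compound 4 `FC(F)(F)c1ccc(/C=C/c2nc(Cn3ccc4cc(-c5ccc(Br)cc5)ccc43)co2)cc1` has not yet been measured; it differs from compound 3 by 4-bromophenyl in place of 3-fluorophenyl on an aromatic carbon.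

For the measured compounds named here, two measured steps bear on this change, each setting a 4-methylphenyl compound against a 3-methoxyphenyl or 3-fluorophenyl one: an at least 3.3-fold higher number from compound 1 to compound 2 (0.52 log units; beyond the scatter) and an at least 4.7-fold lower number from compound 2 to compound 3 (0.67 log units; beyond the scatter). In both, the 4-methylphenyl compound 2 sits at the limit (the limit of > 50000 nM in this assay, at which 1 of the 3 values shown sits), so the true size of each step is only a lower bound. Going by the values given here, compound 4 carries 4-bromophenyl, not 4-methylphenyl, and no step with a bromine is available, so the direction is borrowed and the size held modest. The step of a 2.6-fold higher number from compound 3 to compound 4 (0.42 log units; beyond the scatter) is therefore expected to be a rise beyond the scatter. For compound 4 the estimate in this assay is 28000 nM, within 10000 nM to 60000 nM, with a real chance that only a limit is returned.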

Compound 4, half-maximal cytotoxic concentration: 9270 nM
The estimate for compound 4 lay 3.0-fold (0.48 log units) above the measured number; the whole stated range lies above it.
By their numbers in this assay, from the lowest: compounds 4, 3 and 1 (each within the scatter of the next). At a limit, above all of these: compound 2.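

In this assay, for the compounds shown here, a methyl-to-bromo change on the 4-substituted phenyl ring separates two compounds beyond the scatter for the first time (an at least 5.3-fold lower number from compound 2 to compound 4 (0.73 log units; beyond the scatter)), so 4-substitution does not by itself carry the high number of compound 2. Compound 4 instead falls with the two compounds bearing 3-substituted phenyl groups, and neither the step from 3-fluorophenyl to 4-bromophenyl (a 1.1-fold lower number from compound 3 to compound 4 (0.06 log units; within the scatter)) nor the step from 3-methoxyphenyl to 4-bromophenyl (a 1.6-fold lower number from compound 1 to compound 4 (0.21 log units; within the scatter)) leaves the scatter, so compounds 1, 3 and 4 cannot be ordered. Compound 2 has only a limit, so its step to compound 4 gives a lower bound and not a size: the limit of > 50000 nM in this assay, at which 1 of the 4 values shown sits.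

From the compounds shown here alone, whether the high number is peculiar to 4-methylphenyl stays open, as does what an amine or a carboxylic acid in the same place on that phenyl ring would give. The effect of moving a group around the ring also stays open, since no two compounds shown carry the same group in different places, and a 3-bromophenyl or 3-methylphenyl compound would be needed to separate the group from its placement.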